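Chloro in Place of Hydrogen on Two Related Cores

The source may report more compounds than this note shows. Statements on the series, on what has been measured and on what is new or still open speak of the compounds shown alone.

The measured compounds:
compound 1, `CC(=O)OC/C(=C/c1ccccc1Cl)C(=O)c1ccccc1`, gives 14000 nM in a functional assay on SW1573 cells (Homo sapiens) for inhibition, read by sulforhodamine B assay, with a stated time of 48 h; on this read-out higher numbers stand for weaker inhibition of growth and lower numbers for stronger inhibition of growth;
compound 2, `CC(=O)OC/C(=C/c1ccc(Cl)cc1Cl)C(=O)c1ccccc1`, gives 22000 nM;
compound 3, `C=C(C/C(=C\c1ccccc1)C(=O)c1ccccc1)C(=O)c1ccccc1`, gives 3000 nM.

Compound 1 and compound 2 differ in one place: chloro in place of hydrogen on an aromatic carbon. This change made a step of a 1.6-fold higher number from compound 1 to compound 2 (0.20 log units; within the scatter), so the two values cannot be told apart. Compound 3 carries a different core, and the difference between the two cores is not broken down here; its value is simply the lowest of the three, with compound 1 nearest and compound 2 furthest.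

Compound 4, `C=C(C/C(=C\c1ccc(Cl)cc1)C(=O)c1ccccc1)C(=O)c1ccccc1`, is not yet measured. It differs from compound 3 by chloro in place of hydrogen on an aromatic carbon. Among the measured compounds shown here, this is the same kind of change as the one from compound 1 to compound 2, but not the same: in compound 2 the entering chloro sits meta to a chloro group and para to a large group, whereas in compound 4 it sits only para to a large group, with no second chloro on that ring.

Compound 4 is therefore expected to stay close to compound 3, with an estimated step of a 1.3-fold higher number from compound 3 to compound 4 (0.12 log units; within the scatter), because a 1.6-fold higher number from compound 1 to compound 2 (0.20 log units; within the scatter) lay within the scatter. On that basis compound 4 is expected to give about 4000 nM in this assay, most likely between 2000 nM and 8000 nM.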

Compound 4, concentration for 50% growth inhibition: 6100 nM
Estimate against measurement, compound 4: 1.5-fold (0.18 log units) below, and the stated range covers the measured number.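

In this assay, chloro in place of hydrogen on the core of compound 3 gave a 2.0-fold higher number from compound 3 to compound 4 (0.31 log units; beyond the scatter), a modest weakening of growth inhibition. Set beside the same change on the other core, this step cannot be told apart from the earlier one: the same change on two cores in this assay, a 1.6-fold higher number (0.20 log units; within the scatter) from compound 1 to compound 2 and a 2.0-fold higher number (0.31 log units; beyond the scatter) from compound 3 to compound 4, 1.3-fold (0.11 log units) apart, within the scatter of two such steps. So the change carried from one core to the other with no detectable difference in size on this read-out, but this rests on only one pair of compounds per core, with the entering chloro in different surroundings on the two rings, and it does not show that the two cores would respond alike to any other change.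

The compounds shown leave open whether a different group in place of that hydrogen, such as an amine, a methoxy group or a carboxylic acid, would give steps that also match on the two cores. They also leave open how much of the gap between the cores comes from the parts that differ, since no pair shown separates those parts one at a time.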